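A few compounds are considered here, and "the series" means these few. Any claim that something is new, unique, unknown or untested is made for them only; others in the source may bear on it.

Compound 1 `N#CC1=C(N)Oc2c(c3nc4ccccc4nc3c3ccccc23)C12C(=O)N(Cc1cnnn1-c1ccccc1Br)c1ccccc12` carries a 2-bromophenyl group on an aromatic nitrogen of its core. In a functional assay on HCT-116 cells (Homo sapiens) for antiproliferative activity, read by MTT assay, with a stated time of 48 h (a lower number here means a stronger inhibitor, a higher number a weaker inhibitor), compound 1 gives > 50000 nM, which is a limit of the assay rather than a number. Compound 2 `CCOc1ccc(-n2nncc2CN2C(=O)C3(C(C#N)=C(N)Oc4c3c3nc5ccccc5nc3c3ccccc43)c3ccccc32)cc1` is its 4-ethoxyphenyl counterpart. In this assay compound 2 gives > 50000 nM, again a limit. Compound 3 `Cc1ccc(-n2nncc2CN2C(=O)C3(C(C#N)=C(N)Oc4c3c3nc5ccccc5nc3c3ccccc43)c3ccccc32)c(C)c1` bears a 2,4-dimethylphenyl group in the same place. In this assay compound 3 gives > 50000 nM, also a limit. The steps between them, a step that the two limits leave unreadable from compound 1 to compound 2, a step that the two limits leave unreadable from compound 1 to compound 3 and a step that the two limits leave unreadable from compound 2 to compound 3, therefore cannot be sized, since all three sit at the limit of > 50000 nM in this assay, at which 3 of the 3 values shown sit.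

Compound 4 `N#CC1=C(N)Oc2c(c3nc4ccccc4nc3c3ccccc23)C12C(=O)N(Cc1cnnn1-c1ccc(F)c(Cl)c1)c1ccccc12` differs from compound 1 by 3-chloro-4-fluorophenyl in place of 2-bromophenyl on an aromatic nitrogen. The three measured steps bear on this change only in that each exchange of the aryl group on the aromatic nitrogen left the measured value at the limit, so no shift in either direction is readable. With nothing to suggest that this exchange behaves differently, the expectation for compound 4 is that it too stays at the limit. The step from compound 1 to compound 4 is therefore estimated as a step that the limit leaves unreadable from compound 1 to compound 4. Compound 4 is thus expected to show 60000 nM, within a range of 20000 nM to 200000 nM, most likely reported again only as a limit.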

Compound 4, half-maximal inhibitory concentration: > 50000 nM
Compound 4: only a limit was reported; the forecaster's own chance of this, stated with the estimate: 85%; the middle value lies beyond the limit too.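

In this assay compound 4 gives > 50000 nM, again a limit of the assay. None of the steps to compound 4 from compound 1, compound 2 or compound 3 can be read: the limit of > 50000 nM in this assay, at which 4 of the 4 values shown sit.

The compounds shown leave open whether any aryl group at this place on the shared core gives a measurable value in this assay, and how the four compounds rank.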